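This account rests on a few compounds, and the source may have more. Where it says the series, first, only, none or still open, it means among the compounds named here.

Measured so far in a functional assay on HEK293 cells for activation of melanin-concentrating hormone receptor 1 (Rattus norvegicus), read by inositol phosphate accumulation; a lower number here means that less compound is needed, a higher number that more compound is needed for the effect:
compound 1 `CN(c1ccc2cc(NC(=O)CCc3ccc(C(F)(F)F)cc3)ccc2n1)C1CCCC1` — 350 nM
compound 2 `O=C(CCc1ccc(C(F)(F)F)cc1)Nc1ccc2nc(N3CCC(c4ccccc4)C3)ccc2c1` — 1770 nM

Compound 2 stands highest of the two numbers; its nearest neighbour is compound 1, with the step of a 5.1-fold higher number from compound 1 to compound 2 (0.70 log units; beyond the scatter). Compound 3 `O=C(CCc1ccc(C(F)(F)F)cc1)Nc1ccc2nc(N3CC4CCC3C4)ccc2c1` differs from compound 2 as follows: a group of 7 heavy atoms (6 carbon, 1 nitrogen; one five-membered non-aromatic ring of carbon only, one five-membered non-aromatic ring with 1 hetero atom) in place of a group of 11 heavy atoms (10 carbon, 1 nitrogen; one five-membered non-aromatic ring with 1 hetero atom, one six-membered aromatic ring of carbon only), on an aromatic carbon. Within the data shown here, the only step that bears on this change is a 5.1-fold higher number from compound 1 to compound 2 (0.70 log units; beyond the scatter), which concerns the same position. The entering group, with its 7 heavy atoms, is closer in size to the cyclopentyl(methyl)amino of compound 1 than to 3-phenylpyrrolidin-1-yl, so a lower number, beyond the scatter, is expected. Compound 3 is therefore expected to give 550 nM, with a range of 150 nM to 2000 nM. The expected step is a 3.2-fold lower number from compound 2 to compound 3 (0.51 log units; beyond the scatter).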

Compound 3, half-maximal effective concentration: 150 nM
The estimate for compound 3 lay 3.7-fold (0.56 log units) above the measured number; the measured number falls inside the stated range.
By their numbers in this assay, from the lowest: compound 3; then compound 1; then compound 2.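

In this assay, the group with two five-membered non-aromatic rings gives a 12-fold lower number from compound 2 to compound 3 (1.07 log units; beyond the scatter), so a high number is not general for ring-bearing groups on this aromatic carbon next to the ring nitrogen. It also gives a 2.3-fold lower number from compound 1 to compound 3 (0.37 log units; beyond the scatter), so two groups of 7 heavy atoms do not give the same number, and heavy-atom count alone does not set the outcome here. No measurement at hand accounts for either step.

Open, going by these compounds, is how a piperidin-1-yl or morpholin-4-yl group on this carbon would compare with compound 3.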